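Dropping a methoxy group from a trimethoxyphenyl chalcone

The compounds below may be only part of what the source reports. "The series", "measured", "known", "first", "only" and "open" are said of these compounds alone.

Compound 1 `COc1ccc(-c2cc(/C=C/C(=O)c3cc(OC)c(OC)c(OC)c3)nc3cc(-c4ccccc4)nn23)cc1OC`: 8300 nM
Compound 2 `COc1cc(/C=C/C(=O)c2cc(-c3cc(OC)c(OC)c(OC)c3)n3nc(-c4ccccc4)cc3n2)cc(OC)c1OC`: 17900 nM

Of the compounds shown here, two sharing the same core have been tested in a functional assay on DU-145 cells (Homo sapiens) for antiproliferative activity, read by MTT assay, with a stated time of 24 h; a higher number here means a weaker inhibitor, a lower number a stronger inhibitor. Compound 1 gives 8300 nM, the lower of the two numbers, and compound 2 gives 17900 nM, a gap that lies beyond the scatter of repeated measurements. Nothing more can be said of that pair, as no single-point change links them.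

Compound 3 `COc1ccc(C(=O)/C=C/c2cc(-c3ccc(OC)c(OC)c3)n3nc(-c4ccccc4)cc3n2)cc1OC` has not yet been measured in this assay. Against compound 1 its difference is hydrogen in place of methoxy on an aromatic carbon; cut one bond further out, the same change reads 3,4,5-trimethoxyphenyl to 3,4-dimethoxyphenyl. Within the data shown here, no step between measured compounds here shows what such a change does, so the expectation rests on the two values alone and on the change itself. The account expects a modest weakening, with the step of a 1.8-fold higher number from compound 1 to compound 3 (0.26 log units; within the scatter) estimated to fall a little beyond the scatter. Compound 3 is therefore expected to give about 15000 nM in this assay, within a range from 6000 nM to 40000 nM.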

Compound 3, half-maximal inhibitory concentration: 7200 nM
Beside the measured number, compound 3's estimate is 2.1-fold (0.32 log units) above it, within the range that was stated.
By their numbers in this assay, from the lowest: compounds 3 and 1 (each within the scatter of the next); then compound 2.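

In this assay, among these compounds, this is the first change in one place that can be read, and going from 3,4,5-trimethoxyphenyl to 3,4-dimethoxyphenyl gives a 1.2-fold lower number from compound 1 to compound 3 (0.06 log units; within the scatter). Compound 1 and compound 3 therefore cannot be told apart in this assay, and on this aromatic carbon, hydrogen can stand in place of methoxy with no difference that the measurement can resolve. This holds for this one pair only, and nothing measured here offers an explanation for it.

The compounds shown leave open whether this position is indifferent to what it carries in general, since only methoxy and hydrogen have been compared there, and a hydroxyl group, an amine or a longer chain such as ethoxy could give a different number. They also leave open what happens when a further methoxy group is taken from the same ring, and whether the same replacement would read the same way on the methoxy-bearing ring at the other end of the compound.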